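This account rests on a few compounds, and the source may have more. Where it says the series, first, only, none or still open, it means among the compounds named here.

Compound 1 `CCCn1nc(C)c2c(C)cc(=O)oc21` was examined in a functional assay on the whole organism with Mus musculus as the target, in the writhing test (on this read-out lower numbers stand for an effect already at smaller amounts and higher numbers for an effect only at larger amounts of compound), where compound 1 gives 54.3 mg/kg. Of the two numbers shown it is nominally the lower, yet compound 2 `CCCCCn1nc2oc(=O)cc(C)c2c1C`, which in this assay gives 60.6 mg/kg, sits within the scatter of it. Compound 3 `CCOC(=O)Cc1nnc2oc(O)cc(C)c1-2` returns in this assay only a limit of the assay and not a number, > 100 mg/kg. This is the point recorded as the limit of > 100 mg/kg in this assay, at which 1 of the 3 values shown sits. Compound 4 `CCCCCn1nc(C)c2c(C)cc(=O)oc21` differs from compound 1 in a single place: ethyl in place of hydrogen on a saturated chain carbon, three bonds along the chain from an aromatic nitrogen. Among the measured compounds shown here, no measured pair isolates this change. No step beyond the scatter is expected, a 1.1-fold higher number from compound 1 to compound 4 (0.04 log units; within the scatter), given that compound 2 with its pentyl chain gives 60.6 mg/kg. Compound 4 is accordingly estimated at 60 mg/kg, with a range from 30 mg/kg to 120 mg/kg.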

Compound 4, dose for half-maximal effect: > 100 mg/kg
Compound 4: only a limit was reported (the forecaster's own chance of this, stated with the estimate: 20%); middle value at least 1.6-fold (0.22 log units) from the limit.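

Among the compounds shown here, the first pair to isolate this change, propyl to pentyl, gives in this assay an at least 1.8-fold higher number from compound 1 to compound 4 (0.26 log units; that floor lies within the scatter) and so shows no gain from the added ethyl at this position. How much is lost stays undefined, since compound 4 returns only a limit of the assay: the limit of > 100 mg/kg in this assay, at which 2 of the 4 values shown sit. Where compound 4 truly lies beyond that limit remains open. So does whether a butyl chain, a shorter ethyl chain, or an amine or carboxylic acid at the end of the chain would keep the effect of compound 1.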